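Swapping fluoro for methyl in the E-configured series

A few compounds are considered here, and "the series" means these few. Any claim that something is new, unique, unknown or untested is made for them only; others in the source may bear on it.

Among the measured compounds shown here, in a functional assay on THP-1 cells (Homo sapiens) for inhibition, read by sulforhodamine B assay, with a stated time of 48 h (a lower number here means a stronger inhibitor, a higher number a weaker inhibitor), compound 2 `COc1ccc(/C(=C/c2ccc(F)cc2)c2cccc3ccccc23)c(OC)c1OC` gives 18900 nM, the highest of the two numbers measured so far. Its partner compound 1 `COc1ccc(/C(=C\c2ccc(F)cc2)c2cccc3ccccc23)c(OC)c1OC` has the same atoms and bonds and in this assay gives 9080 nM; the step of a 2.1-fold higher number from compound 1 to compound 2 (0.32 log units; beyond the scatter) rests solely on (the fact that compounds 1 and 2 differ only in the configuration as drawn). Compound 3 `COc1ccc(/C(=C/c2ccc(C)cc2)c2cccc3ccccc23)c(OC)c1OC` keeps the drawn configuration of compound 2 and alters one substituent: methyl in place of fluoro on an aromatic carbon. For the measured compounds named here, the single measured step concerns the double-bond geometry alone and offers no guidance about a change at this aromatic carbon, so no measured step bears directly on the move from compound 2 to compound 3. With nothing in the measured data pointing either way, the account expects for compound 3 in this assay a step of a 1.1-fold lower number from compound 2 to compound 3 (0.02 log units; within the scatter) that stays within the scatter. Compound 3 is therefore estimated at 18000 nM, with a range from 6000 nM to 50000 nM.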

Compound 3, half-maximal inhibitory concentration: > 20000 nM
Compound 3 ended at the assay's limit; the forecaster's own chance of this, stated with the estimate: 15%; middle value at least 1.1-fold (0.04 log units) from the limit.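

In this assay compound 3 gives > 20000 nM, which is a limit of the assay and not a number. The change from 4-fluorophenyl to 4-methylphenyl reads as an at least 1.0-fold higher number from compound 2 to compound 3 (0.02 log units; that floor lies within the scatter), so at this aromatic carbon, para to a large group, methyl in place of fluoro brings no gain in inhibition, something the earlier pair, which differs only in double-bond geometry, could not show. That step is a floor and not a measured size, for one reason: the limit of > 20000 nM in this assay, at which 1 of the 3 values shown sits.

On these data alone, how far the number rises with methyl remains open, as does how methyl reads in the Z-configured form. The compounds shown also leave open how an amine or a carboxylic acid at this aromatic carbon would read in this assay.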